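Fluoro for Methoxy: Expecting Compound 4

The compounds below may be only part of what the source reports. "The series", "measured", "known", "first", "only" and "open" are said of these compounds alone.

Compound 3 `CNc1nc(Nc2ccc(OC)cc2)nc2ccccc12` gives 26100 nM in an ADME assay on HepG2 cells (Homo sapiens) for inhibition, with a stated time of 48 h; a lower number here means that less compound is needed, a higher number that more compound is needed for the effect. Compound 2 `COc1ccc(Nc2ncc3c(NCCCO)cccc3n2)cc1` gives 15900 nM in this assay, a number that sits within the scatter of compound 3, so the two cannot be told apart here. Compound 1 `COc1ccc(Nc2ncc3c(N4CCN(C)CC4)cccc3n2)cc1` returns only a limit of this assay, > 40000 nM, and not a number. Among the measured compounds shown here, the single measured step, an at least 2.5-fold lower number from compound 1 to compound 2 (0.40 log units; beyond the scatter), changes a group on the shared core rather than on the ring that carries the methoxy. Compound 4 `CNc1nc(Nc2ccc(F)cc2)nc2ccccc12` differs from compound 3 by fluoro in place of methoxy on an aromatic carbon. For the measured compounds named here, no measured step touches this place, so a step no larger than the scatter is expected, a 1.0-fold lower number from compound 3 to compound 4 (0.00 log units; within the scatter). Compound 4 is therefore estimated at 26000 nM, between 10000 nM and 70000 nM, with a real chance that only a limit is reported.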

Compound 4, half-maximal effective concentration: 16200 nM
Estimate against measurement, compound 4: 1.6-fold (0.21 log units) above; the range from low to high includes it.
By their numbers in this assay, from the lowest: compounds 2, 4 and 3 (each within the scatter of the next). At a limit, above all of these: compound 1.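

Fluoro in place of methoxy, para to a large group, is the first measured change on this ring, and it gives a 1.6-fold lower number from compound 3 to compound 4 (0.21 log units; within the scatter) in this assay. So at this place, replacing the methoxy with a single fluorine atom has no effect that can be read. Nothing given here points to a cause for this result.

Going by these compounds, whether an amine, a carboxylic acid or a longer chain at this place would also leave the number within the scatter stays open. So does whether the same swap behaves alike on the core of compound 2.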